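Swapping 3,5-Dihydroxyphenyl for Naphthalen-1-yl on the Shared Core

A few compounds are considered here, and "the series" means these few. Any claim that something is new, unique, unknown or untested is made for them only; others in the source may bear on it.

Compound 1 `CCOC(=O)CC1C(C(=O)OCC)=C(N)Oc2ccccc21` gives 91400 nM
Compound 2 `CCCc1ccc2c(c1)C(CC(=O)OCC)C(C(=O)OCC)=C(N)O2` gives 57300 nM
Compound 3 `CCOC(=O)CC1C(C(=O)OCC)=C(N)Oc2ccc(-c3cc(O)cc(O)c3)cc21` gives 18300 nM

In a functional assay on Jurkat cells (Homo sapiens) for cytotoxicity, with a stated time of 48 h (a higher number here means a weaker inhibitor, a lower number a stronger inhibitor), compound 3 has the lowest of the three numbers, and its steps to both other compounds lie beyond the scatter. Still to be measured is compound 4 `CCOC(=O)CC1C(C(=O)OCC)=C(N)Oc2ccc(-c3cccc4ccccc34)cc21` which carries naphthalen-1-yl in place of 3,5-dihydroxyphenyl on an aromatic carbon. The difference is naphthalen-1-yl in place of 3,5-dihydroxyphenyl on an aromatic carbon and the rest of the structure stays the same.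

Within the data shown here, three measured steps bear on this change. Propyl in place of hydrogen gave a 1.6-fold lower number from compound 1 to compound 2 (0.20 log units; within the scatter) and 3,5-dihydroxyphenyl in place of hydrogen gave a 5.0-fold lower number from compound 1 to compound 3 (0.70 log units; beyond the scatter) as a modest change. Swapping propyl for 3,5-dihydroxyphenyl gave a 3.1-fold lower number from compound 2 to compound 3 (0.50 log units; beyond the scatter) which is also modest. Among the measured compounds shown here, no measured compound carries naphthalen-1-yl, and none shows what happens without the two hydroxyl groups of compound 3. Only a small change is therefore expected in this assay leaning slightly toward a lower number and quite possibly within the scatter. The estimate corresponds to an expected 1.4-fold lower number from compound 3 to compound 4 (0.15 log units; within the scatter) and no more than that. For compound 4 the estimated value is 13000 nM with an expected range from 4500 nM to 38000 nM for now.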

Compound 4, half-maximal inhibitory concentration: 5830 nM
Beside the measured number, compound 4's estimate is 2.2-fold (0.35 log units) above it; the measured number falls inside the stated range.
By their numbers in this assay, from the lowest: compound 4; then compound 3; then compounds 2 and 1 (each within the scatter of the next).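

In this assay, this position on the aromatic carbon, meta to a fused ring and para to a fused ring, does not need 3,5-dihydroxyphenyl for the lowest number in the series: with naphthalen-1-yl, which has 0 hydrogen-bond donors and 0 hydrogen-bond acceptors, the number falls further (a 3.1-fold lower number from compound 3 to compound 4 (0.50 log units; beyond the scatter)). Among these compounds, the change also widens the range of effects seen at this position, with a clear drop against propyl (a 9.8-fold lower number from compound 2 to compound 4 (0.99 log units; beyond the scatter)) and the only step printed as large against hydrogen (a 16-fold lower number from compound 1 to compound 4 (1.20 log units; beyond the scatter)). Among these four compounds, both groups with an aromatic ring give lower numbers than hydrogen or propyl, no compound goes against this, and naphthalen-1-yl now stands beyond the scatter of all three others.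

No supporting data are available to explain why the number falls with this change. The compounds shown do not separate the loss of the two hydroxyl groups from the gain of the second aromatic ring, so a plain phenyl group at this position would be the missing link, while naphthalen-2-yl would show whether the point of attachment on the naphthalene matters.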